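The source may report more compounds than this note shows. Statements on the series, on what has been measured and on what is new or still open speak of the compounds shown alone.

Two compounds have so far been run through an ADME assay on Huh7.5.1 cells (Homo sapiens) for cytotoxicity, read by ATP content, with a stated time of 48 h; on this read-out higher numbers stand for lower toxicity in this test and lower numbers for higher toxicity in this test. Compound 1 `Cc1cc(C)c(-c2nc(CN3CCC(C(=O)NCCCN4C[C@H](C)C[C@H](C)C4)CC3)c(C)o2)c(C)c1` gives 6570 nM in this assay. Compound 2 `Cc1cccc(Cl)c1-c1nc(CN2CCC(C(=O)NCCCN3CCC(C)(C)CC3)CC2)c(C)o1` gives 11700 nM in this assay, and the two numbers lie within the usual scatter of each other, so neither can be set apart from the other on cytotoxicity. Compound 3 `COc1ccc(-c2nc(CN3CCC(C(=O)NCCCN4C[C@H](C)C[C@H](C)C4)CC3)c(C)o2)cc1OC` has not yet been measured. It differs from compound 1 in a single place: 3,4-dimethoxyphenyl in place of 2,4,6-trimethylphenyl on an aromatic carbon. Among the measured compounds shown here, no measured pair in this set shows what such a change does in this assay, so any expectation rests on compound 1 alone. For the measured compounds named here, the chemist expects the step of a 1.2-fold higher number from compound 1 to compound 3 (0.09 log units; within the scatter) to stay within the scatter, in no clear direction, because compound 1 gives 6570 nM and nothing among the measured compounds points away from that number. Compound 3 is therefore estimated at 8000 nM, with a range from 3000 nM to 22000 nM.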

Compound 3, half-maximal cytotoxic concentration: 57200 nM
For compound 3 the middle estimate is 7.2-fold (0.85 log units) below the measured one, outside the stated range (above it).
By their numbers in this assay, from the lowest: compounds 1 and 2 (each within the scatter of the next); then compound 3.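

In this assay, among the compounds shown here, 3,4-dimethoxyphenyl in place of 2,4,6-trimethylphenyl on an aromatic carbon of the five-membered aromatic ring gives an 8.7-fold higher number from compound 1 to compound 3 (0.94 log units; beyond the scatter), the first step in this set that lies beyond the scatter. This shows that the number in this test responds to the aryl group at this position, which the two earlier compounds could not show. The change goes from 0 to 2 hydrogen-bond acceptors, but nothing measured here bears on why the number rises.

From the compounds shown here alone, whether a plain phenyl, a single methoxy group or a pyridine ring at this position would stay near compound 1 or near compound 3 remains open. Going by these compounds, it is also open whether the same change would give a step of this size in a compound with a different amine.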